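The source may hold more compounds than are shown below. What is called first, only, known or untested is meant among the compounds shown, and "the series" means these compounds.

Measured compounds:
- compound 1 `Fc1ccc(-c2noc(C3CCc4c(nnn4-c4ccc(F)cc4)C3)n2)cc1` with 15.9 nM in a functional assay on U2OS cells for positive allosteric modulation of metabotropic glutamate receptor 5 (Homo sapiens), read by calcium flux, in the presence of a further agent that is not named here; on this read-out higher numbers stand for an effect only at larger amounts of compound and lower numbers for an effect already at smaller amounts
- compound 2 `CN1CCC(n2nnc3c2CCC(c2nc(-c4ccc(F)cc4)no2)C3)CC1` with 3980 nM in this assay

For the measured compounds named here, compound 2 stands at the higher of the two numbers so far; its nearest neighbour is compound 1, and the step of a 250-fold higher number from compound 1 to compound 2 (2.40 log units; beyond the scatter) separates them, a move well beyond the scatter brought about by putting 1-methylpiperidin-4-yl in place of 4-fluorophenyl on an aromatic nitrogen of the shared core.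

Compound 3 `CC1(n2nnc3c2CCC(c2nc(-c4ccc(F)cc4)no2)C3)CCOCC1` differs from compound 2 in one place: 4-methyloxan-4-yl in place of 1-methylpiperidin-4-yl on an aromatic nitrogen. Going by the values given here, no measured step exchanges one saturated six-membered ring for another at this position, so the only step that bears on it is the one from compound 1 to compound 2, which shows that this aromatic nitrogen is sensitive to what it carries, but swaps an aromatic group for a saturated one and therefore only bounds what is likely. A change between two saturated rings is expected to be smaller than that step. Compound 3 is expected to give 1000 nM in this assay, within 150 nM to 6000 nM, a step of a 4.0-fold lower number from compound 2 to compound 3 (0.60 log units; beyond the scatter) that is estimated rather than known.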

Compound 3, half-maximal effective concentration: 10 nM
Estimate against measurement, compound 3: 100-fold (2.00 log units) above; the whole stated range lies above it.
By their numbers in this assay, from the lowest: compounds 3 and 1 (each within the scatter of the next); then compound 2.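

In this assay, the change shows that the loss seen earlier on this aromatic nitrogen does not come with a saturated ring as such: a 400-fold lower number from compound 2 to compound 3 (2.60 log units; beyond the scatter) is a large step between two saturated six-membered rings that carry the same counts of heavy atoms and hydrogen-bond acceptors and no net charge. Compound 3 also places a saturated ring on this nitrogen without leaving the range of the aromatic 4-fluorophenyl group, since a 1.6-fold lower number from compound 1 to compound 3 (0.20 log units; within the scatter) stays within the scatter, so among these three compounds an aromatic group is not needed here for a low number, and compound 2 is the one that stands apart. Nothing measured on these compounds accounts for the large gap between the two saturated rings.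

The 4-methyloxan-4-yl and 1-methylpiperidin-4-yl groups differ both in the ring hetero atom and in where the methyl sits, so the step does not say which of these carries the change. Oxan-4-yl without the methyl, 4-methylpiperidin-4-yl or an unsubstituted piperidin-4-yl on the same nitrogen would separate the two, and how far this holds for an open chain such as tert-butyl stays open as well.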